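The source may hold more compounds than are shown below. What is called first, only, known or untested is meant among the compounds shown, and "the series" means these compounds.

Compound 1 `CC(C)CCn1ccc(-c2ccc(OC3CCCC3)c(Cl)c2)c(C#N)c1=O` and compound 2 `CC(C)CCn1ccc(-c2ccc(OC3CCOCC3)c(Cl)c2)c(C#N)c1=O` share one core and differ only at the group on the aromatic oxygen. In a functional assay on CHO cells for positive allosteric modulation of metabotropic glutamate receptor 2 (Homo sapiens), read by scintillation counting and GTPgammaS binding, with a stated time of 30 min (a higher number here means a larger maximal response, a lower number a smaller maximal response), compound 1 gives 199%, and compound 2 gives 197%; the step of a number 2 percentage points lower from compound 1 to compound 2 (within the scatter) leaves the two side by side, within the scatter of each other. Compound 3 `CC(C)CCn1ccc(-c2ccc(NC3CCOCC3)c(Cl)c2)c(C#N)c1=O` carries a change of a different kind, ((oxan-4-yl)amino in place of (oxan-4-yl)oxy on an aromatic carbon). No measured step swaps an oxygen linker for a nitrogen linker, so no shown step bears directly on it; the only expectation is no change beyond the scatter, a step of a number 2 percentage points lower from compound 2 to compound 3 (within the scatter). The estimate for compound 3 is therefore 195%, between 160% and 230%.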

Compound 3, largest response reached (Emax), in percent of the reference or control that the assay uses: 247%
Compound 3: middle estimate off by 52 percentage points, on the low side; the whole stated range lies below it.
By their numbers in this assay, from the lowest: compounds 2 and 1 (each within the scatter of the next); then compound 3.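

The atom joining the ring to the aromatic carbon matters more here than the ring itself: changing the ring on the oxygen stayed within the scatter, yet (oxan-4-yl)amino in place of (oxan-4-yl)oxy gives a number 50 percentage points higher from compound 2 to compound 3 (beyond the scatter) in this assay. The step with both changes, a number 48 percentage points higher from compound 1 to compound 3 (beyond the scatter), is also large. The new group has one hydrogen-bond donor where the old one had none, but no measurement here explains the rise. Open, going by these compounds, is whether a cyclopentylamino group would match the oxan-4-ylamino group. A nitrogen carrying a methyl group, or a sulfur linker, would test whether the amine hydrogen is needed.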